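A Hydroxyphenyl Variant of a Boron-Bearing Chalcone

The compounds below may be only part of what the source reports. "The series", "measured", "known", "first", "only" and "open" are said of these compounds alone.

Compound 1 `O=C(/C=C/c1ccc2c(c1)B(O)OC2)c1ccc(F)cc1` gives 2800 nM in a functional assay on HCT-116 cells (Homo sapiens) for cytotoxicity, read by MTT assay, with a stated time of 48 h (a lower number here means a stronger inhibitor, a higher number a weaker inhibitor), the lowest number among the three measured compounds. Compound 2 `CCc1ccc(C(=O)/C=C/c2ccc3c(c2)B(O)OC3)cc1` gives 10900 nM, and compound 3 `CCOC(=O)c1ccc(C(=O)/C=C/c2ccc3c(c2)B(O)OC3)cc1` gives 7600 nM. The two steps of a 3.9-fold higher number from compound 1 to compound 2 (0.59 log units; beyond the scatter) and a 2.7-fold higher number from compound 1 to compound 3 (0.43 log units; beyond the scatter) both show a modest weakening once the fluoro is replaced. Compound 4 `O=C(/C=C/c1ccc2c(c1)B(O)OC2)c1cccc(O)c1` has not been measured. It differs from compound 1 by 3-hydroxyphenyl in place of 4-fluorophenyl on a carbonyl carbon. Within the data shown here, no measured step exchanges the whole aryl group or brings in a 3-hydroxyphenyl, so those two steps bear only loosely on this change, yet both point the same way: changing the fluoro costs a little. Compound 4 is therefore expected to show a small weakening, a 1.6-fold higher number from compound 1 to compound 4 (0.21 log units; within the scatter), with an estimate of 4500 nM and a range from 1800 nM to 11000 nM.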

Compound 4, half-maximal inhibitory concentration: 6500 nM
Beside the measured number, compound 4's estimate is 1.4-fold (0.16 log units) below it; the range from low to high includes it.
By their numbers in this assay, from the lowest: compound 1; then compounds 4, 3 and 2 (each within the scatter of the next).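

In this assay, a hydroxyl-bearing aryl group on the carbonyl carbon also gives a weaker result, with a 2.3-fold higher number from compound 1 to compound 4 (0.37 log units; beyond the scatter). Until now, only replacements of the fluoro had been seen; this step shows that a full exchange for 3-hydroxyphenyl, which adds a hydrogen-bond donor and acceptor, also fails to beat 4-fluorophenyl. No available evidence accounts for this difference. The step cannot separate losing the fluoro from gaining the hydroxyl. As far as these compounds go, how an amine or a carboxylic acid on this aryl ring would compare also remains open.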